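Changing the Amide Aryl Group: Expected Cytotoxicity Shift

The compounds below may be only part of what the source reports. "The series", "measured", "known", "first", "only" and "open" are said of these compounds alone.

Of the compounds shown here, two sharing a common core have been tested in a toxicity assay on HepG2 cells (Homo sapiens) for inhibition, read by CellTiter-Glo, with a stated time of 48 h; a higher number here means a weaker inhibitor, a lower number a stronger inhibitor. Compound 1 `COc1ccc2nc(C)cc(OC3CCN(c4ccccc4)C3=O)c2c1` gives 100000 nM in this assay. Compound 2 `COc1ccc2nc(C)cc(OCC(=O)Nc3ccccc3)c2c1` gives 39800 nM in this assay. Compound 2 therefore holds the lower of the two numbers; its nearest neighbour, compound 1, sits at a higher number, and the gap between them lies beyond the usual scatter.

Compound 3 `COc1ccc2nc(C)cc(OCC(=O)Nc3cc(C)c(F)c(C)c3)c2c1` has not yet been measured. It differs from compound 2 in one place: 4-fluoro-3,5-dimethylphenyl in place of phenyl on an amide-type nitrogen. Among the measured compounds shown here, no step between measured compounds matches this change, so there is no direct precedent for it in this assay. Because compound 2 already shows the lower number with 39800 nM, a modest further move toward a lower number is expected for compound 3, although one that may not clear the scatter. Compound 3 is thus estimated at 20000 nM in this assay, with a range from 7000 nM to 60000 nM. The expected step is a 2.0-fold lower number from compound 2 to compound 3 (0.30 log units; within the scatter).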

Compound 3, half-maximal inhibitory concentration: > 100000 nM
Compound 3 gave a limit, no number; the forecaster's own chance of this, stated with the estimate: 15%; middle value at least 5.0-fold (0.69 log units) from the limit.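

In this assay, the aryl group on the amide-type nitrogen proves able to move the reading: 4-fluoro-3,5-dimethylphenyl in place of phenyl gives an at least 2.5-fold higher number from compound 2 to compound 3 (0.40 log units; beyond the scatter). Among the compounds shown here, compound 1 and compound 2 offered no step between them, so this is the first direct sign that the group at this position matters and that this change leads toward weaker inhibition of the cells, not stronger. The reading for compound 3 is a limit and not a number, so the step fixes the direction but not the full size of the change: the limit of > 100000 nM in this assay, at which 1 of the 3 values shown sits.

The single change brings in a fluorine and two methyl groups together, so the compounds shown cannot assign the shift to any one of them, and a 4-fluorophenyl or a 3,5-dimethylphenyl group on the same nitrogen would be needed to separate them. They also leave open how this position responds to an aryl ring carrying an amine or a carboxylic acid, and whether the same change would act in the same direction on the core of compound 1.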